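This account rests on a few compounds, and the source may have more. Where it says the series, first, only, none or still open, it means among the compounds named here.

Measured compounds:
compound 1 `Cc1ccc(S/C(=C/c2c[nH]c3ccccc23)C(=O)c2ccc(Br)cc2)cc1` gives 10000 nM in a functional assay on DU-145 cells (Homo sapiens) for inhibition, read by trypan blue exclusion, with a stated time of 96 h; a higher number here means a weaker inhibitor of growth, a lower number a stronger inhibitor of growth.
compound 2 `Cc1ccc(S/C(=C/c2c[nH]c3ccc(Br)cc23)C(=O)c2ccc(Br)cc2)cc1` gives 1000 nM in this assay.
compound 3 `Cc1ccc(S/C(=C/c2c[nH]c3ccc(Br)cc23)C(=O)c2ccc(Cl)cc2)cc1` gives 1000 nM in this assay.

Compound 4 `Cc1ccc(S/C(=C/c2c[nH]c3ccccc23)C(=O)c2ccc(Cl)cc2)cc1` has not yet been measured. The cores of compound 2 and compound 3 differ by chloro in place of bromo on an aromatic carbon, and the step of no change at the digits printed from compound 2 to compound 3 (within the scatter) sits within the scatter. The change from compound 3 to compound 4 is hydrogen in place of bromo on an aromatic carbon; the same change is made from compound 2 to compound 1, as hydrogen in place of bromo on an aromatic carbon, and there it gave a 10-fold higher number from compound 2 to compound 1 (1.00 log units; beyond the scatter). The place of the change is described in the same words for both pairs, so the change is the same. Among the measured compounds shown here, for compound 4 in this assay a step of the same size is expected, a 10-fold higher number from compound 3 to compound 4 (1.00 log units; beyond the scatter), because compound 3 starts from 1000 nM and the earlier step of a 10-fold higher number from compound 2 to compound 1 (1.00 log units; beyond the scatter) is the only guide. Compound 4 is estimated at 10000 nM, between 4000 nM and 25000 nM.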

Compound 4, concentration for 50% growth inhibition: 10000 nM
For compound 4 middle estimate and measured number coincide at the digits printed, and the stated range covers the measured number.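

In this assay, hydrogen in place of bromo on the aromatic carbon of the fused system gives a 10-fold higher number from compound 3 to compound 4 (1.00 log units; beyond the scatter), and this step carries over between the two cores: the same change on two cores in this assay, a 10-fold higher number (1.00 log units; beyond the scatter) from compound 2 to compound 1 and a 10-fold higher number (1.00 log units; beyond the scatter) from compound 3 to compound 4, 1.0-fold (0.00 log units) apart, within the scatter of two such steps
Chloro in place of bromo on the other aromatic ring gives no change at the digits printed from compound 1 to compound 4 (within the scatter), which also holds on both cores: the same change on two cores in this assay, no change at the digits printed (within the scatter) from compound 2 to compound 3 and no change at the digits printed (within the scatter) from compound 1 to compound 4, 1.0-fold (0.00 log units) apart, within the scatter of two such steps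
This agreement rests on two cores that differ only by those two halogens, so it does not show that either step would hold on a core changed elsewhere.

Still open, as far as these compounds go, is how an amine or a carboxylic acid would compare with bromo and hydrogen at that place on the fused system. Also open, from the compounds shown here alone, is whether either step would persist with a longer chain in place of the methyl group.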